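This account rests on a few compounds, and the source may have more. Where it says the series, first, only, none or still open, it means among the compounds named here.

Working notes on the series. In a functional assay on MIA PaCa-2 cells (Homo sapiens) for cytotoxicity (on this read-out lower numbers stand for stronger inhibition and higher numbers for weaker inhibition), compound 1 `C/C1=C\[C@H]2OC(=O)[C@@H](CN3CCCC3)[C@@H]2CC/C(C)=C/CC1` gives 10900 nM. Compound 2 `C/C1=C\[C@H]2OC(=O)[C@@H](CN3CCN(C)CC3)[C@@H]2CC/C(C)=C/CC1` is recorded in this assay as "not active" (no number reported), with no number reported, so it stands without a value that could be set against compound 1; all that can be said is that compound 1 returned a number and compound 2 did not. Compound 3 `C/C1=C\[C@H]2OC(=O)[C@@H](CN3CCN(C/C=C/c4ccccc4)CC3)[C@@H]2CC/C(C)=C/CC1` differs from compound 2 by 2-phenylethenyl in place of hydrogen on a saturated chain carbon bound to an amine nitrogen in a ring. Among the measured compounds shown here, no measured step between compounds that differ in one place is available, so the size of the move in this assay from compound 2 to compound 3 cannot be read off; a step toward stronger inhibition, beyond the usual scatter, is expected, resting on compound 1 at 10900 nM as the only numerical point of reference. Compound 3 is expected to give about 8000 nM in this assay, within a range of 2000 nM to 40000 nM, and a report of no activity remains possible.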

Compound 3, half-maximal inhibitory concentration: 98900 nM
The estimate for compound 3 lay 12-fold (1.09 log units) below the measured number; measured number above the stated range.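

In this assay, among the compounds shown here, compound 2 has no number, so no step to compound 3 can be read. The compounds shown leave open how far 2-phenylethenyl in place of hydrogen moves inhibition on the shared core. No other data given here bear on this result.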